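This account rests on a few compounds, and the source may have more. Where it says the series, first, only, none or still open, it means among the compounds named here.

In a functional assay on HCT-116 cells (Homo sapiens) for cytotoxicity, read by MTT assay, with a stated time of 72 h (a lower number here means a stronger inhibitor, a higher number a weaker inhibitor), compound 1 `O=S(=O)(c1ccccc1)c1nc2ccccc2nc1N1CCc2ccccc2C1`, which has an unsubstituted phenyl on its sulfonyl group, gives 18700 nM. Compound 2 `O=S(=O)(c1ccc(Br)cc1)c1nc2ccccc2nc1N1CCc2ccccc2C1` is known only as a limit of the assay, > 50000 nM, so it has no exact number. Compound 3 `O=S(=O)(c1ccc(F)cc1)c1nc2ccccc2nc1N1CCc2ccccc2C1` differs from compound 2 by fluoro in place of bromo on an aromatic carbon, turning 4-bromophenyl into 4-fluorophenyl: fluoro in place of bromo on an aromatic carbon. Within the data shown here, one measured step bears on this change. Adding the bromo gave an at least 2.6-fold higher number from compound 1 to compound 2 (0.42 log units; beyond the scatter), which is beyond the scatter and moves towards weaker inhibition. With that bromo gone, a move back towards a lower number in this assay is expected, perhaps of modest size. Fluoro is not hydrogen, however, so an exact return is not assured. The expected step is an at least 2.0-fold lower number from compound 2 to compound 3 (0.30 log units; that floor lies within the scatter). For compound 3 the estimated value is 25000 nM, with a likely range from 9000 nM to 50000 nM.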

Compound 3, half-maximal inhibitory concentration: 16600 nM
Compound 3: middle estimate off by 1.5-fold (0.18 log units), on the high side; the measured number falls inside the stated range.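

In this assay, this place on the phenyl ring does not turn against every group, since going from hydrogen to fluoro gives a 1.1-fold lower number from compound 1 to compound 3 (0.05 log units; within the scatter). Exchanging bromo for fluoro gives an at least 3.0-fold lower number from compound 2 to compound 3 (0.47 log units; beyond the scatter), so among these three compounds the weaker reading goes with the 4-bromophenyl group alone, not with simply having a substituent at this place. Compound 2 is known only as a limit, so this step has a floor and no exact size: the limit of > 50000 nM in this assay, at which 1 of the 3 values shown sits.

From the compounds shown here alone, what a chloro, a methoxy or an amine would do at this place remains open, so two halogens and hydrogen cannot yet show a trend. Also open, going by these compounds, is whether a fluoro on another carbon of this ring would read the same as the 4-fluorophenyl group of compound 3.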